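The compounds below may be only part of what the source reports. "The series", "measured", "known", "first", "only" and "open" are said of these compounds alone.

Working notes on the series, read in a physicochemical assay for solubility, in phosphate buffer, with a stated time of 24 h, at pH 7.4, tested at 200 uM; a lower number here means a less soluble compound, a higher number a more soluble compound. Compound 1 `Oc1cc(Oc2cccc(-c3cccc(O)c3F)n2)ccc1F` gives > 200000 nM, which is a limit of the assay and not a number. Compound 3 `Oc1cc(Nc2cccc(-c3cccc(O)c3F)n2)ccc1F` gives > 200000 nM, which is also a limit. The ceiling of the set is therefore (the limit of > 200000 nM in this assay, at which 2 of the 3 values shown sit). Within the data shown here, compound 2 `Cc1cc(-c2ccc3ccc(C(=O)c4ccc(F)c(O)c4)nc3c2)ccc1O` gives 13000 nM, the only true number among the three measured compounds.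

Compound 4 `O=C(c1ccc(F)c(O)c1)c1ccc2ccccc2n1` comes from compound 2 by hydrogen in place of 4-hydroxy-3-methylphenyl on an aromatic carbon. Among the measured compounds shown here, no measured pair differs in a single place, so the size of this step has no direct precedent and the expectation rests on the structural change alone. Compound 2 at 13000 nM leaves room for a rise in this assay. The expected change is a 3.8-fold higher number from compound 2 to compound 4 (0.59 log units; beyond the scatter), an estimated rise beyond the scatter. For compound 4 the estimated solubility is 50000 nM, with an expected range of 15000 nM to 200000 nM.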

Compound 4, solubility: > 200000 nM
Compound 4 gave a limit, no number; the forecaster's own chance of this, stated with the estimate: 20%; at least 4.0-fold (0.60 log units) between middle value and limit.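

Among these compounds, replacing 4-hydroxy-3-methylphenyl with hydrogen on this aromatic carbon gives the first single-place comparison, and in this assay it reads as a large rise (an at least 15-fold higher number from compound 2 to compound 4 (1.18 log units; beyond the scatter)). From the compounds shown here alone, for compound 4 the value (> 200000 nM) is a limit of the assay and not a number, so the true size of the step stays unknown beyond what is printed with it. Among the compounds shown here, compound 2 remains the only compound with a true number, and compound 4 now also sits at the ceiling: (the limit of > 200000 nM in this assay, at which 3 of the 4 values shown sit).

Going by these compounds, whether a small group on this carbon, such as an amine or a carboxylic acid, would also reach that ceiling stays open. Also open, on these data alone, is whether a plain phenyl here, without the hydroxy and methyl groups, would read nearer compound 2 or compound 4.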